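Chloro for methoxy on the arylpiperazine of compound 1

A few compounds are considered here, and "the series" means these few. Any claim that something is new, unique, unknown or untested is made for them only; others in the source may bear on it.

Compound 1, `COc1ccccc1N1CCN(CCCn2nc(-n3cnc4ccccc43)ccc2=O)CC1`, has been measured in an assay on cell membranes from brain for binding affinity to Adrenergic receptor alpha-1 (Rattus norvegicus), read by radioligand binding (a lower number here means a stronger inhibitor, a higher number a weaker inhibitor), where compound 1 gives 6.5 nM. Among the three measured compounds it holds the second highest number. Compound 2, `COc1ccccc1N1CCN(CCCCCCCn2nc(-n3cnc4ccccc43)ccc2=O)CC1`, which carries the longer heptyl linker, gives 1.7 nM in this assay, a number well apart from that of compound 1. Compound 3, `O=c1ccc(-n2cnc3ccccc32)nn1CCN1CCN(c2ccccc2Cl)CC1`, the ethyl-linked chlorophenyl analogue, gives 70.4 nM; its number lies furthest from compound 1. Compound 3 differs from compound 1 in two places at once, so these two values alone cannot be split into the share of the linker and the share of the aryl substituent.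

Compound 4, `O=c1ccc(-n2cnc3ccccc32)nn1CCCN1CCN(c2ccccc2Cl)CC1`, keeps the propyl linker of compound 1 and differs from it only in one place: chloro in place of methoxy on an aromatic carbon. Among the compounds with values here, no measured pair shows this change on its own. Within the data shown here, the only chlorophenyl compound, compound 3, gives 70.4 nM, which points toward a weaker inhibitor. Compound 4 is therefore expected to be the weaker inhibitor, with an estimated step of a 3.1-fold higher number from compound 1 to compound 4 (0.49 log units; beyond the scatter) beyond the scatter. Among the measured compounds shown here, that expected gap is smaller than the one seen between compound 1 and compound 3. The estimated value of compound 4 is 20 nM, expected to fall between 6 nM and 60 nM.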

Compound 4, inhibition constant: 15.2 nM
Estimate against measurement, compound 4: 1.3-fold (0.12 log units) above; measured number inside the range.
By their numbers in this assay, from the lowest: compound 2; then compound 1; then compound 4; then compound 3.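

With the propyl linker held fixed, the change from 2-methoxyphenyl to 2-chlorophenyl can now be read on its own in this assay: the step is a 2.3-fold higher number from compound 1 to compound 4 (0.37 log units; beyond the scatter). The methoxy group is therefore not essential at this place ortho to a large group, since compound 4, with chloro, still gives 15.2 nM. Among the chlorophenyl compounds, the ethyl-linked compound 3 gives 70.4 nM, a higher number than the propyl-linked compound 4 at 15.2 nM, so the chloro change alone does not reach the number seen for compound 3.

Nothing measured here explains the step from methoxy to chloro. Open questions remain whether the step would recur on the heptyl linker of compound 2, and what a fluoro, methyl or hydroxyl group would give at this place.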